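Hydroxy to chloro at the end of the heptyl-bearing chain

The source may hold more compounds than are shown below. What is called first, only, known or untested is meant among the compounds shown, and "the series" means these compounds.

In a functional assay on HCT-116 cells (Homo sapiens) for antiproliferative activity, read by MTT assay, with a stated time of 48 h (on this read-out higher numbers stand for weaker inhibition and lower numbers for stronger inhibition), compound 1 `CCC(CCO)n1cnc2c(Cl)ncnc21` reads > 50000 nM, which is a limit of the assay and not a number. Compound 2 `CCCCCCCCC[C@H](CCO)n1cnc2c(Cl)ncnc21` gives 450 nM, and compound 3 `CCCCCCCCCC(CCO)n1cnc2c(Cl)ncnc21` gives 890 nM. For the measured compounds named here, compound 3 therefore stands level with compound 2 in this assay, since a 2.0-fold higher number from compound 2 to compound 3 (0.30 log units; within the scatter) and the only other value is a limit. The next structure, compound 4 `CCCCCCCCCC(CCCl)n1cnc2c(Cl)ncnc21`, carries one change: chloro in place of hydroxy on a saturated chain carbon, three bonds along the chain from an aromatic nitrogen. In other words, 2-hydroxyethyl gives way to 2-chloroethyl. Going by the values given here, no measured step touches this position. The large step of an at least 56-fold lower number from compound 1 to compound 3 (1.74 log units; beyond the scatter) comes from heptyl in place of hydrogen, and compound 4 keeps that heptyl. The configuration step between compound 2 and compound 3 stays within the scatter and says nothing about the swap. Activity in the range of compound 3 at 890 nM is thus the working expectation, with no step beyond the scatter. The expected step is a 1.3-fold higher number from compound 3 to compound 4 (0.13 log units; within the scatter), and this estimate is poorly constrained. For compound 4 the estimated value is 1200 nM, with an expected range of 350 nM to 4500 nM.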

Compound 4, half-maximal inhibitory concentration: 10200 nM
Compound 4: the middle estimate sits 8.5-fold (0.93 log units) below what was measured; measured number above the stated range.
By their numbers in this assay, from the lowest: compounds 2 and 3 (each within the scatter of the next); then compound 4. At a limit, above all of these: compound 1.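

The end of the 2-hydroxyethyl chain, untouched by any earlier step, turns out to matter: in this assay, chloro in place of hydroxy gives an 11-fold higher number from compound 3 to compound 4 (1.06 log units; beyond the scatter). Compound 4 keeps the heptyl, so the heptyl alone does not hold the activity seen for compound 3, and the group at this place also counts. For the compounds shown here, the hydroxy-bearing compounds 2 and 3 are the only compounds with the heptyl and a hydroxy, and compound 4 is the only one with the chloro, so this reading rests on a single swap. Nothing measured here gives a cause for this step.

From the compounds shown here alone, it remains open whether the loss follows from the hydroxy leaving or from the chloro entering. Going by these compounds, an amine, a methoxy or a carboxylic acid at the same place would help separate the two, and the chain length between the hydroxy and the core also remains open.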